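Benzylsulfanyl in Place of Isobutylamino: Expected Cytotoxicity

The source may report more compounds than this note shows. Statements on the series, on what has been measured and on what is new or still open speak of the compounds shown alone.

Compound 1 `Nc1nc(NC2CC2)c2ncn(/C=C3/CC3(CO)CO)c2n1` shows > 20000 nM in an ADME assay on CCRF-HSB-2 cells (Homo sapiens) for cytotoxicity, with a stated time of 7 days; on this read-out lower numbers stand for higher toxicity in this test and higher numbers for lower toxicity in this test; this is a limit of the assay, not a number.
Compound 2 `CCCCCCCCSc1nc(N)nc2c1ncn2/C=C1/CC1(CO)CO` gives 60000 nM in this assay.
Compound 3 `CC(C)CNc1nc(N)nc2c1ncn2/C=C1/CC1(CO)CO` shows > 20000 nM in this assay; this too is a limit of the assay, not a number.

Compound 3 therefore stands at the limit of > 20000 nM in this assay, at which 2 of the 3 values shown sit. Among the compounds with values here, none of the measured steps can be read in size: a step that the two limits leave unreadable from compound 1 to compound 3, a step that the limit leaves unreadable from compound 1 to compound 2 and a step that the limit leaves unreadable from compound 2 to compound 3. Compound 4 `Nc1nc(SCc2ccccc2)c2ncn(/C=C3/CC3(CO)CO)c2n1` has not yet been measured; the change is benzylsulfanyl in place of isobutylamino on an aromatic carbon. Within the data shown here, compound 2 is the only measured compound that, like compound 4, carries a group joined through sulfur, and its value is a number rather than a limit, yet the step from compound 2 to compound 3 remains unreadable. No direction beyond the scatter can be expected with confidence; every measured compound shows low toxicity in this assay. Compound 4 is expected at 40000 nM, within 15000 nM to 120000 nM, an estimated step that the limit leaves unreadable from compound 3 to compound 4.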

Compound 4, half-maximal cytotoxic concentration: > 100000 nM
Compound 4 was reported as a limit (the forecaster's own chance of this, stated with the estimate: 50%); middle value at least 2.5-fold (0.39 log units) away from the limit.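

Compound 4 carries benzylsulfanyl on the same aromatic carbon that holds octylsulfanyl in compound 2, and its result is a limit of the assay, not a number: the limit of > 100000 nM in this assay, at which 1 of the 4 values shown sits.

Between these two sulfur-linked groups, the change gives an at least 1.6-fold higher number from compound 2 to compound 4 (0.22 log units; that floor lies within the scatter), so a phenyl in place of the heptyl leaves toxicity in this test low, but this floor alone does not separate the two compounds. The steps from compound 1 and from compound 3 to compound 4 cannot be read, so the amino-linked and sulfur-linked groups on this carbon stay unranked.

It remains open whether any group on this aromatic carbon can bring a value clearly lower than those shown. A short methylsulfanyl group, or a benzyloxy group with oxygen in place of the sulfur, could help to show how much the chain and the linking atom each count.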